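Swapping a Saturated Ring for an Aromatic One

The source may report more compounds than this note shows. Statements on the series, on what has been measured and on what is new or still open speak of the compounds shown alone.

Compound 2 `N#CC1=C(NCN2CCCCC2)N(c2ccccc2)C(=O)N2CCCCC(N3CCCC3)C12` is one of two compounds tested in a functional assay on the whole organism (strain albino) for inhibition, with Rattus norvegicus as the target, read by paw edema, with a stated time of 1 h, at a dose of 20 mmol/kg by the intraperitoneal route (a lower number here means less inhibition, a higher number more inhibition at the dose given (going by the name of the read-out)), where compound 2 gives 29.7%. Compound 1 `COc1ccc(N/C=N/C2=C(C#N)C3C(N4CCCC4)CCCCN3C(=O)N2c2ccccc2)cc1` gives 20.6% in this assay, so compound 2 holds the higher of the two numbers, but the gap to compound 1 lies within the scatter, and the two cannot be ranked. Compound 3 `N#CC1=C(/N=C/Nc2ccccc2)N(c2ccccc2)C(=O)N2CCCCC(N3CCCC3)C12` has not yet been measured. It differs from compound 2 in one place: a group of 9 heavy atoms (7 carbon, 2 nitrogen; one six-membered aromatic ring of carbon only) in place of a group of 8 heavy atoms (6 carbon, 2 nitrogen; one six-membered non-aromatic ring with 1 hetero atom), on a double-bonded ring carbon. Within the data shown here, the only measured step that speaks to this change is a number 9.1 percentage points higher from compound 1 to compound 2 (within the scatter), which exchanged an aromatic-ring group for the saturated-ring group of compound 2 and moved the read-out by less than the scatter. Putting an aromatic-ring group back in the same place is therefore expected to move this assay by no more than the scatter, in either direction, giving a number 6.7 percentage points lower from compound 2 to compound 3 (within the scatter) as the expected step. Compound 3 is estimated at 23% in this assay, with a range from 10% to 36%.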

Compound 3, a percentage reported as inhibition, in the whole organism at one dose (the size of the read-out at that dose, not a potency): 35.2%
The estimate for compound 3 lay 12.2 percentage points below the measured number; the measured number falls inside the stated range.
By their numbers in this assay, from the lowest: compounds 1, 2 and 3 (each within the scatter of the next, the first and the last beyond it).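

In this assay, placing the aromatic-ring group on the double-bonded ring carbon in place of ((piperidin-1-yl)methyl)amino gives a number 5.5 percentage points higher from compound 2 to compound 3 (within the scatter), and the reverse kind of exchange gave a number 9.1 percentage points higher from compound 1 to compound 2 (within the scatter), so neither exchange between a saturated ring and an aromatic ring moves the read-out beyond the usual scatter. Among these compounds, the clearer signal comes from a much smaller change on the aromatic ring itself: hydrogen in place of methoxy on an aromatic carbon gives a number 14.6 percentage points higher from compound 1 to compound 3 (beyond the scatter), a modest step, yet the only single-place step so far that lies beyond the scatter. Nothing measured here accounts for either step.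

The compounds shown leave open whether this step is specific to methoxy, and a fluorine, a chlorine or a methyl on the same aromatic ring would help to answer that. Also open, from the compounds shown here alone, is how a morpholine ring or a simple dimethylamino group would read in place of ((piperidin-1-yl)methyl)amino, and whether any of these differences would hold at other doses, as each number here comes from a single dose.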